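Isoxazole-pyrazole series: aryl swap at the isoxazole carbon

The source may report more compounds than this note shows. Statements on the series, on what has been measured and on what is new or still open speak of the compounds shown alone.

Measured so far:
- compound 1 `c1ccc(-c2cc(-c3cnn(C4CCNCC4)c3)on2)cc1`: 100000 nM
- compound 2 `Clc1cnccc1-c1cc(-c2cnn(C3CCNCC3)c2)on1`: 200 nM

In an assay on isolated protein for positive allosteric modulation of Neuronal acetylcholine receptor; alpha4/beta2 (Homo sapiens) (on this read-out lower numbers stand for an effect already at smaller amounts and higher numbers for an effect only at larger amounts of compound), compound 2 gives 200 nM, the lowest of the two numbers shown; compound 1 gives 100000 nM, and the step of a 500-fold lower number from compound 1 to compound 2 (2.70 log units; beyond the scatter) is large and well beyond the scatter. Compound 2 thus stands as the better of the two measured compounds, with nothing closer to compare it against.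

Compound 3 `Clc1cccc(Cl)c1-c1cc(-c2cnn(C3CCNCC3)c2)on1` differs from compound 2 in one place: 2,6-dichlorophenyl in place of 3-chloropyridin-4-yl on an aromatic carbon. One chlorine is kept on the six-membered ring and a second is added, while the ring nitrogen is given up. Among the compounds with values here, the only measured step that bears on this position is a 500-fold lower number from compound 1 to compound 2 (2.70 log units; beyond the scatter), which shows that the six-membered ring on this carbon can move the number a great deal, and that the chlorine-bearing ring is far better than bare phenyl. Within the data shown here, no step isolates the ring nitrogen from the chlorine, so the direction for compound 3 is uncertain; because a 500-fold lower number from compound 1 to compound 2 (2.70 log units; beyond the scatter) was driven by a ring that carried chlorine, compound 3 is expected to stay much closer to compound 2 than to compound 1, with a modest loss as the central case, a 3.0-fold higher number from compound 2 to compound 3 (0.48 log units; beyond the scatter). Compound 3 is estimated at 600 nM, within 100 nM to 5000 nM.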

Compound 3, half-maximal effective concentration: 410 nM
For compound 3 the middle estimate is 1.5-fold (0.17 log units) above the measured one, and the stated range covers the measured number.
By their numbers in this assay, from the lowest: compound 2; then compound 3; then compound 1.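

In this assay, the 2,6-dichlorophenyl ring keeps most of the gain over bare phenyl, with a 240-fold lower number from compound 1 to compound 3 (2.39 log units; beyond the scatter). Against 3-chloropyridin-4-yl the cost is much smaller, at a 2.1-fold higher number from compound 2 to compound 3 (0.31 log units; beyond the scatter), so on this aromatic carbon next to the ring nitrogen, a six-membered aromatic ring of carbon only can still give a number far lower than that of compound 1, and a nitrogen in that ring is not required for most of the gain. Nothing at hand accounts for either step, and the shares of the chlorines and the ring nitrogen remain unassigned.

The compounds shown leave open how a phenyl ring with a single chlorine, or a pyridin-4-yl ring with no chlorine, would read here, and no single step yet separates the chlorine from the ring nitrogen. Also open, going by these compounds, is whether methyl, methoxy or trifluoromethyl groups in place of the two chlorines on the phenyl ring would hold the number near that of compound 3.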